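Notes on a methoxy-to-chloro step in a cytotoxicity series

The source may hold more compounds than are shown below. What is called first, only, known or untested is meant among the compounds shown, and "the series" means these compounds.

Measured compounds:
compound 1, `COc1ccc(C2=NN(C3=NC(=O)/C(=C4\C(=O)Nc5ccc(Br)cc54)S3)C(c3ccc(OC)cc3)C2)cc1`, gives 480 nM
compound 2, `COc1ccc(C2=NN(C3=NC(=O)/C(=C4\C(=O)Nc5ccc(Cl)cc54)S3)C(c3ccc(OC)cc3)C2)cc1`, gives 500 nM

In a functional assay on cells (Cancer cell lines, Homo sapiens) for cytotoxicity, read by sulforhodamine B assay, with a stated time of 48 h (on this read-out higher numbers stand for weaker inhibition of growth and lower numbers for stronger inhibition of growth), compound 2 gives 500 nM, the top number of the two, but the other number, from compound 1, lies within the scatter of it: a 1.0-fold higher number from compound 1 to compound 2 (0.02 log units; within the scatter).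

Compound 3, `COc1ccc(C2=NN(C3=NC(=O)/C(=C4\C(=O)Nc5ccc(Cl)cc54)S3)C(c3ccc(Cl)cc3)C2)cc1`, differs from compound 2 by chloro in place of methoxy on an aromatic carbon. Within the data shown here, the one measured step, a 1.0-fold higher number from compound 1 to compound 2 (0.02 log units; within the scatter), exchanges one halogen for another on a different ring and stays within the scatter; no measured step exchanges a methoxy for a chloro anywhere, so the data give no direction for this change. The working expectation is therefore no step beyond the scatter, with wide uncertainty. Compound 3 is expected to give about 500 nM, in the range 200 nM to 1500 nM. This estimate means no change at the digits printed from compound 2 to compound 3 (within the scatter).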

Compound 3, concentration for total growth inhibition: 470 nM
Compound 3: middle estimate off by 1.1-fold (0.03 log units), on the high side; measured number inside the range.
By their numbers in this assay, from the lowest: compounds 3, 1 and 2 (each within the scatter of the next).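

In this assay, replacing methoxy with chloro on this aromatic carbon, para to a large group, gives a 1.1-fold lower number from compound 2 to compound 3 (0.03 log units; within the scatter), so the read-out does not separate 4-methoxyphenyl from 4-chlorophenyl here. The earlier compounds shown here offered only a halogen exchange on a different ring, a 1.0-fold higher number from compound 1 to compound 2 (0.02 log units; within the scatter), whereas this result shows that a non-halogen group and a halogen at this position also fall within the scatter of each other. No measured evidence on these compounds bears on this result.

The compounds shown leave open whether this position would stay equally flat with an amine, a carboxylic acid or a longer alkyl chain in place of the chloro. They also leave open whether exchanging the remaining methoxy of compound 3 for chloro would give a step beyond the scatter.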